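A few compounds are considered here, and "the series" means these few. Any claim that something is new, unique, unknown or untested is made for them only; others in the source may bear on it.

Measured compounds:
- compound 1, `O=C(Nc1ccccn1)c1cc(=O)[nH]c2cc(Br)ccc12`: 11000 nM
- compound 2, `O=C(Nc1cccc(F)c1)c1cc(=O)[nH]c2cc(Br)ccc12`: 8900 nM

In a functional assay on KYSE-70 cells for antiproliferative activity against KYSE-70 cell line (Homo sapiens), read by MTT assay, with a stated time of 72 h (on this read-out lower numbers stand for stronger inhibition and higher numbers for weaker inhibition), compound 1 gives 11000 nM and compound 2 gives 8900 nM. Among the measured compounds shown here, the only measured step, a 1.2-fold lower number from compound 1 to compound 2 (0.09 log units; within the scatter), lies within the scatter, so the two numbers cannot be ranked against each other. Compound 2 is the lowest of the two numbers, with compound 1 nearest to it, but within the scatter.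

Compound 3, `Cc1ccc(-c2ccc3c(C(=O)Nc4cccc(F)c4)cc(=O)[nH]c3c2)cc1`, has not yet been measured in this assay. It differs from compound 2 as follows: 4-methylphenyl in place of bromo on an aromatic carbon. For the measured compounds named here, no measured step touches this position of the shared core; the single known step concerns the group on the amide-type nitrogen instead. There is therefore no direct guide to the size or direction of the change, and any expectation is weak. Compound 3 is estimated at 5000 nM, in the range 1000 nM to 25000 nM, which means an expected step of a 1.8-fold lower number from compound 2 to compound 3 (0.25 log units; within the scatter).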

Compound 3, half-maximal inhibitory concentration: > 20000 nM
Compound 3: only a limit was reported; the forecaster's own chance of this, stated with the estimate: 5%; middle value at least 4.0-fold (0.60 log units) away from the limit.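

Among the compounds shown here, this is the first change at this aromatic carbon of the shared core, and unlike the change on the amide-type nitrogen, it has a readable effect. In this assay, 4-methylphenyl in place of bromo gives an at least 2.2-fold higher number from compound 2 to compound 3 (0.35 log units; beyond the scatter), so this position does affect the result, and here the larger group goes with weaker inhibition. Compound 3 has only a limit of the assay rather than a number, so the full size of this step stays unknown: the limit of > 20000 nM in this assay, at which 1 of the 3 values shown sits.

From the compounds shown here alone, one pair cannot separate the loss of bromo from the arrival of the new ring, and it remains open how a smaller group such as methyl, an amine or a carboxylic acid would behave at this carbon. Going by these compounds, it is also open whether 4-methylphenyl would have the same effect with pyridin-2-yl on the amide-type nitrogen.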